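Adding a Third Methoxy Group to Compound 2

This account rests on a few compounds, and the source may have more. Where it says the series, first, only, none or still open, it means among the compounds named here.

Measured so far:
compound 1 `COc1cc(/C=C/C2CC(=O)C=CO2)cc(OC)c1OC` — 155 uM
compound 2 `COc1cc(/C=C/C2CC=CC(=O)O2)cc(OC)c1` — 8.8 uM

In an ADME assay on HaCaT cells (Homo sapiens) for inhibition, read by sulforhodamine B assay, with a stated time of 48 h (on this read-out lower numbers stand for stronger inhibition of growth and higher numbers for weaker inhibition of growth), compound 2 gives 8.8 uM, the lowest of the two numbers in hand. Its nearest neighbour is compound 1, which in this assay gives 155 uM, a gap beyond the scatter; compound 1 differs from compound 2 in more than one place, so no single change can be read from that gap.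

Compound 3 `COc1cc(/C=C/C2CC=CC(=O)O2)cc(OC)c1OC` has not yet been measured in this assay. It differs from compound 2 by methoxy in place of hydrogen on an aromatic carbon. Within the data shown here, no measured pair shows this change on its own, so the expected step from compound 2 to compound 3 is a 1.4-fold higher number from compound 2 to compound 3 (0.13 log units; within the scatter), a small move that is expected to stay within the scatter. On that basis compound 3 is estimated at 12 uM, within a range of 4 uM to 40 uM.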

Compound 3, concentration for growth inhibition (reported as GI): 21.6 uM
Beside the measured number, compound 3's estimate is 1.8-fold (0.26 log units) below it; measured number inside the range.
By their numbers in this assay, from the lowest: compound 2; then compound 3; then compound 1.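

In this assay, methoxy in place of hydrogen on an aromatic carbon, ortho to two methoxy groups and para to a group of 9 heavy atoms, gives a 2.5-fold higher number from compound 2 to compound 3 (0.39 log units; beyond the scatter) and so weakens growth inhibition at this position. With the aromatic part held the same, exchanging one group of 7 heavy atoms for another, each a six-membered non-aromatic ring with 1 hetero atom, gives a 7.2-fold lower number from compound 1 to compound 3 (0.86 log units; beyond the scatter) and shows that the read-out also depends on that end of the molecule. No available evidence explains either step.

The compounds shown leave open whether a hydroxyl group, an amine or a longer alkoxy chain at this same place would give a step like that of methoxy. They also leave open whether hydrogen in place of this methoxy on the core of compound 1 would move the number in the same direction.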